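A few compounds are considered here, and "the series" means these few. Any claim that something is new, unique, unknown or untested is made for them only; others in the source may bear on it.

Of the compounds shown here, three built on a shared core have so far been tested in a functional assay on MOLT-4 cells (Homo sapiens) for inhibition, read by sulforhodamine B assay, with a stated time of 48 h; a higher number here means a weaker inhibitor of growth, a lower number a stronger inhibitor of growth. Compound 1 `O=C(Nc1cccc(-n2cc(-c3ccncc3)c(-c3ccc(Cl)c(O)c3)n2)c1)Nc1cccc(C(F)(F)F)c1` gives 1920 nM in this assay. Compound 2 `COc1cc(-c2nn(-c3cccc(NC(=O)Nc4cc(C(F)(F)F)cc(C(F)(F)F)c4)c3)cc2-c2ccncc2)ccc1Cl` gives 1080 nM. Compound 3 `COc1cc(-c2nn(-c3cccc(NC(=O)c4cccc(C(F)(F)F)c4)c3)cc2-c2ccncc2)ccc1Cl` gives 2010 nM, the highest of the three numbers, yet its gap to compound 1 and its gap to compound 2 both lie within the usual scatter of repeated measurements, so no ranking of the three can be read from these figures; they look alike.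

Compound 4 `COc1cc(-c2nn(-c3cccc(NC(=O)Nc4ccc(Cl)c(Cl)c4)c3)cc2-c2ccncc2)ccc1Cl` has not yet been measured. It differs from compound 3 in one place: (3,4-dichlorophenyl)amino in place of 3-(trifluoromethyl)phenyl on a carbonyl carbon. Among the measured compounds shown here, no two of the measured compounds differ in only one place, so there is no measured step that reports the effect of such a change on its own. For the measured compounds named here, the only guide is that the three measured values all sit within the scatter of one another despite their differences in the outer part of the molecule.

The step from compound 3 to compound 4 in this assay is therefore expected to be a 1.4-fold lower number from compound 3 to compound 4 (0.16 log units; within the scatter), which is to say nothing beyond the scatter, with at most a slight lean toward a lower number because compound 2 gives 1080 nM while compound 3 gives 2010 nM. Compound 4 is expected to give about 1400 nM in this assay, with a likely range from 500 nM to 4000 nM.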

Compound 4, concentration for 50% growth inhibition: 1100 nM
The estimate for compound 4 lay 1.3-fold (0.10 log units) above the measured number; measured number inside the range.
By their numbers in this assay, from the lowest: compounds 2, 4, 1 and 3 (each within the scatter of the next).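

In this assay, among the compounds shown here, putting (3,4-dichlorophenyl)amino in place of 3-(trifluoromethyl)phenyl on a carbonyl carbon gives a 1.8-fold lower number from compound 3 to compound 4 (0.26 log units; within the scatter), the first direct reading of a change at this position, and it shows that this exchange of outer groups leaves the growth-inhibition figure within the scatter. The step alters two things at once, since the entering group brings a nitrogen with one hydrogen-bond donor and two chlorines, while the leaving group carries three fluorines, so the result describes the whole exchange and cannot be divided between those parts. No available measurement explains the result or links it to any property of either group.

The compounds shown leave open how (3,4-dichlorophenyl)carbonyl, which keeps the dichlorophenyl ring without the added nitrogen, would compare on the same core. They also leave open whether a more different group on this carbonyl carbon, such as a piperazine or a phenyl ring bearing a carboxylic acid, would give a step beyond the scatter.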